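The compounds below may be only part of what the source reports. "The series", "measured", "known", "first", "only" and "open" are said of these compounds alone.

Only a thin set of results exists for this family of compounds in an ADME assay on HUVEC cells (Homo sapiens) for cytotoxicity, read by MTT assay, with a stated time of 72 h; a lower number here means a stronger inhibitor, a higher number a weaker inhibitor. Compound 1 `COc1cc(-c2nccn2C(C)C)cc(OC)c1OC` stands as "not determined" (no result reported), and compound 2 `COc1ccc(-n2ccnc2-c2cc(OC)c(OC)c(OC)c2)cc1[N+](=O)[O-]` stands as "not determined" (no result reported), so neither offers a figure to compare. Compound 3 `COc1cc(-c2nccn2-c2ccc(C)cc2)cc(OC)c1OC` gives > 100000 nM, which is a limit of the assay and not a number. On these data alone, it is therefore the only reference point, and its true position on the scale remains unknown.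

Compound 4 `COc1ccc(-n2ccnc2-c2cc(OC)c(OC)c(OC)c2)cc1` differs from compound 3 in a single place: methoxy in place of methyl on an aromatic carbon. This is methoxy in place of methyl on an aromatic carbon, para to a large group, so 4-methylphenyl becomes 4-methoxyphenyl.

Among the measured compounds shown here, no measured pair of compounds shows what a change like this does in this assay, so any forecast is loose. With compound 3 at the limit of > 100000 nM as the sole anchor, a modest move towards a lower number, meaning stronger inhibition, is expected, and the change may not exceed the usual scatter. A second result reported only as a limit is also quite possible. In numbers, the estimated change is an at least 1.4-fold lower number from compound 3 to compound 4 (0.15 log units; that floor lies within the scatter). For compound 4 the expected value is 70000 nM, with an estimated range from 10000 nM to 200000 nM.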

Compound 4, half-maximal inhibitory concentration: > 50000 nM
Compound 4: a limit, no number; the forecaster's own chance of this, stated with the estimate: 55%; the middle value is on the limit's open side.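

Among the compounds shown here, compound 3 and compound 4 are both reported only as limits of the assay, not as numbers, so no step between them can be read. The compounds shown leave open where either one truly stands in this assay, and so what the change from 4-methylphenyl to 4-methoxyphenyl does to the value.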